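This account rests on a few compounds, and the source may have more. Where it says the series, first, only, none or still open, it means among the compounds named here.

Two compounds with a shared core carrying a hydroxamic acid have been measured: compound 1 `Cc1cccc(CN2CC=C(CCC(=O)NO)C2=O)c1` and compound 2 `CC(C)(C)c1ccc(CCCN2CC=C(CCC(=O)NO)C2=O)cc1`. In a functional assay on MDA-MB-231 cells (Homo sapiens) for inhibition, read by sulforhodamine B assay (a higher number here means a weaker inhibitor of growth, a lower number a stronger inhibitor of growth), compound 1 gives 1990 nM. For the measured compounds named here, the only other measured compound, compound 2, gives 2210 nM in this assay; the gap between the two lies within the usual scatter of such measurements, so the pair count as alike, and neither stands apart from the other.

The unmeasured compound 3 `O=C(CCC1=CCN(Cc2cccc(Cl)c2)C1=O)NO` differs from compound 1 in one place: chloro in place of methyl on an aromatic carbon. Going by the values given here, no pair of measured compounds shows this change, so nothing here tells how large its effect is. One heavy atom replaces one heavy atom, with no change in ring, donor, acceptor or charge count. The step from compound 1 to compound 3 is therefore expected to be no change at the digits printed from compound 1 to compound 3 (within the scatter), none beyond the scatter in this assay. Compound 3 is expected to give about 1990 nM, within a range of 900 nM to 4400 nM.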

Compound 3, concentration for 50% growth inhibition: 1990 nM
Estimate against measurement, compound 3: no gap at the digits printed; the measured number falls inside the stated range.
By their numbers in this assay, from the lowest: compounds 1, 3 and 2 (each within the scatter of the next).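

In this assay, for the compounds shown here, the swap of methyl for chloro on an aromatic carbon, meta to a large group, shows no change at the digits printed from compound 1 to compound 3 (within the scatter) and so gives the first direct reading of a single change at this position. In this one pair, chloro and methyl cannot be told apart by growth inhibition of these cells, so this position accepts either group without a shift beyond the scatter. Nothing measured here speaks to why the two groups match.

As far as these compounds go, whether an amine, a carboxylic acid or a longer chain on this same carbon would also leave the number unmoved remains open. A single pair also cannot say whether this swap would behave the same way on another carbon of the ring or on a different core.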